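A few compounds are considered here, and "the series" means these few. Any claim that something is new, unique, unknown or untested is made for them only; others in the source may bear on it.

In an ADME assay on Vero 76 cells (Chlorocebus sabaeus) for cytotoxicity, read by neutral red uptake (on this read-out higher numbers stand for lower toxicity in this test and lower numbers for higher toxicity in this test), compound 1 `CC[C@@H](Nc1nc(SC)nc2c1ccn2[C@H]1[C@H](O)[C@H](O)[C@]2(CO)C[C@H]12)C1CC1` gives > 50000 nM, which is a limit of the assay. Compound 2 `OC[C@@]12C[C@@H]1[C@@H](n1ccc3c(NC(C4CCC4)C4CCC4)nc(Cl)nc31)[C@H](O)[C@@H]2O` gives 86000 nM. Among the compounds with values here, compound 3 `O[C@@H]1[C@H](O)[C@@H]2C[C@@H]2[C@H]1n1cnc2c(NCC(C3CC3)C3CC3)nc(Cl)nc21` gives 10000 nM, the lowest number of the series so far and beyond the scatter from compound 2. Compound 4 `O[C@@H]1[C@H](O)[C@@H]2C[C@@H]2[C@H]1n1cnc2c(NC(C3CCC3)C3CCC3)nc(Cl)nc21` has dicyclobutylmethyl in place of 2,2-dicyclopropylethyl on a nitrogen on an aromatic ring. Compound 2 carries the same dicyclobutylmethyl group on a different core and gives 86000 nM, so a rise is expected in this assay, covering only part of the distance to that number. The expected step of a 3.0-fold higher number from compound 3 to compound 4 (0.48 log units; beyond the scatter) is upward and moderately beyond the scatter. For compound 4 the estimated value is 30000 nM, with an expected range of 11000 nM to 90000 nM.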

Compound 4, half-maximal cytotoxic concentration: 17000 nM
Compound 4: the middle estimate sits 1.8-fold (0.25 log units) above what was measured; the measured number falls inside the stated range.
By their numbers in this assay, from the lowest: compounds 3 and 4 (each within the scatter of the next); then compound 2.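

In this assay, dicyclobutylmethyl in place of 2,2-dicyclopropylethyl on a nitrogen on an aromatic ring gives a 1.7-fold higher number from compound 3 to compound 4 (0.23 log units; within the scatter). On this core, then, two four-membered rings in place of two three-membered rings do not separate the compounds at this position. Compound 2 carries the same dicyclobutylmethyl group on a different core, so its number cannot be assigned to that group alone.

On these data alone, whether an amine or a carboxylic acid on this nitrogen would shift the number remains open. Compound 1 cannot be placed in the order, as its value is a limit: the limit of > 50000 nM in this assay, at which 1 of the 4 values shown sits.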